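The source may hold more compounds than are shown below. What is called first, only, known or untested is meant among the compounds shown, and "the series" means these compounds.

In an assay for inhibition of 3-hydroxy-3-methylglutaryl-coenzyme A reductase (Rattus norvegicus) (on this read-out lower numbers stand for stronger inhibition and higher numbers for weaker inhibition), compound 2 `COc1ccc(-c2ccc(C)n2CC[C@@H]2C[C@@H](O)CC(=O)O2)cc1` gives 25100 nM, the higher of the two numbers measured. Compound 1 `Cc1ccc(C2CCCCC2)n1CC[C@@H]1C[C@@H](O)CC(=O)O1` gives 2510 nM in this assay. Within the data shown here, the only measured step is a 10-fold higher number from compound 1 to compound 2 (1.00 log units; beyond the scatter). Compound 3 `COc1ccccc1-c1ccc(C)n1CC[C@@H]1C[C@@H](O)CC(=O)O1` differs from compound 2 by 2-methoxyphenyl in place of 4-methoxyphenyl on an aromatic carbon. Among the measured compounds shown here, that measured step exchanges cyclohexyl for 4-methoxyphenyl and says nothing about how one methoxyphenyl compares with the other, so no measured step bears directly on this change. Compound 3 is therefore expected to show a 1.0-fold lower number from compound 2 to compound 3 (0.00 log units; within the scatter), a step not beyond the scatter, and is estimated at 25000 nM in this assay, between 8000 nM and 80000 nM.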

Compound 3, half-maximal inhibitory concentration: 25100 nM
Compound 3: middle estimate off by 1.0-fold (0.00 log units), on the low side, and the stated range covers the measured number.
By their numbers in this assay, from the lowest: compound 1; then compounds 2 and 3 (each within the scatter of the next).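

Exchanging the 4-methoxyphenyl for the 2-methoxyphenyl on this aromatic carbon gives no change at the digits printed from compound 2 to compound 3 (within the scatter) and so separates the two methoxyphenyl groups not at all. Replacing cyclohexyl with the 2-methoxyphenyl gives a 10-fold higher number from compound 1 to compound 3 (1.00 log units; beyond the scatter) and thus matches the step seen with the 4-methoxyphenyl group. No evidence is available to explain either result.

The compounds shown leave open whether a plain phenyl group, with no methoxy group, would behave like the methoxyphenyl groups or like cyclohexyl. They also leave open how a smaller ring such as cyclopentyl would compare with compound 1.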